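From compound 2 to compound 4: a side chain swap

A few compounds are considered here, and "the series" means these few. Any claim that something is new, unique, unknown or untested is made for them only; others in the source may bear on it.

Among the measured compounds shown here, in an ADME assay on BE(2)-C cells (Homo sapiens) for cytotoxicity, read by MTT assay, with a stated time of 20 h (a higher number here means that more compound is tolerated, a lower number that less compound is tolerated), compound 2 `CN1CCN(C(=O)C2CCN(C(=O)c3cc4ccccc4n3Cc3ccc(Cl)cc3)CC2)CC1` gives 75600 nM as the only actual number so far. Compound 1 `O=C(NCc1ccncc1)C1CCN(C(=O)c2cc3ccccc3n2Cc2ccc(Cl)cc2)CC1` reads > 100000 nM and that is a limit of the assay, not a number. Compound 3 `CN1CCC(CNC(=O)C2CCN(C(=O)c3cc4ccccc4n3Cc3ccc(Cl)cc3)CC2)CC1` reads > 50000 nM and that too is a limit.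

The next member is compound 4 `Cn1ccc(CNC(=O)C2CCN(C(=O)c3cc4ccccc4n3Cc3ccc(Cl)cc3)CC2)n1`, reached from compound 2 through ((1-methyl-1H-pyrazol-3-yl)methyl)amino in place of 4-methylpiperazin-1-yl on a carbonyl carbon and in words this is ((1-methyl-1H-pyrazol-3-yl)methyl)amino in place of 4-methylpiperazin-1-yl on a carbonyl carbon.

The nearest measured change sits on the same carbonyl carbon: an at least 1.3-fold lower number from compound 1 to compound 2 (0.12 log units; that floor lies within the scatter) with 4-methylpiperazin-1-yl in place of ((pyridin-4-yl)methyl)amino. Read in reverse, that step resembles the move to compound 4, but it offers only a floor on its size. The steps a step that the two limits leave unreadable from compound 1 to compound 3 and a step that the limit leaves unreadable from compound 2 to compound 3 give no size for comparison.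

On the strength of an at least 1.3-fold lower number from compound 1 to compound 2 (0.12 log units; that floor lies within the scatter) alone, no step beyond the scatter is expected in this assay and any lean would be towards a higher number. The estimated move is a 1.2-fold higher number from compound 2 to compound 4 (0.08 log units; within the scatter) and it is expected to stay within the scatter. Compound 4 is expected at 90000 nM with an estimated range from 45000 nM to 180000 nM and it may well end up only as a limit.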

Compound 4, half-maximal cytotoxic concentration: > 100000 nM
Compound 4 gave a limit, no number; the forecaster's own chance of this, stated with the estimate: 60%; middle value at least 1.1-fold (0.04 log units) from the limit.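

In this assay compound 4 gives > 100000 nM, which is a limit of the assay and not a number. The swap on the carbonyl carbon gives an at least 1.3-fold higher number from compound 2 to compound 4 (0.12 log units; that floor lies within the scatter). Among the compounds shown here, this is the first readable step leading away from compound 2, the only compound with an actual number, and it shows that a five-membered aromatic ring on a methylamino link can replace the six-membered non-aromatic ring of 4-methylpiperazin-1-yl without a step beyond the scatter being established, although only a floor on its size is available. The steps reaching compound 4 from compound 1 and from compound 3 cannot be read, because both ends of each step are limits: the limit of > 100000 nM in this assay, at which 2 of the 4 values shown sit.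

On these data alone, the change to compound 4 alters the ring, the link and the amide hydrogen together, so the step cannot be assigned to any one of them, and its true size remains open. As far as these compounds go, whether morpholin-4-yl on the same carbonyl carbon, or a longer chain between the amide nitrogen and the 1-methyl-1H-pyrazol-3-yl ring, would give an actual number in this assay also remains open.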